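Ring closure of the amine on the shared core

This account rests on a few compounds, and the source may have more. Where it says the series, first, only, none or still open, it means among the compounds named here.

Compound 1 `C=C(C)CN(CC)Cc1c(C(F)(F)F)nc2n(-c3c(C)cc(C)cc3C)c(Cl)cn12` carries the shared core with an ethyl(2-methylprop-2-en-1-yl)amino group on a saturated chain carbon bound to an aromatic carbon. In an assay on cells for displacement of a labelled ligand from corticotropin-releasing factor receptor 1 (Homo sapiens), with a stated time of 100 min (a higher number here means a weaker inhibitor, a lower number a stronger inhibitor), compound 1 gives 67 nM, the highest of the two numbers recorded so far. Compound 2 `Cc1cc(C)c(-n2c(Cl)cn3c(CN(CCC(F)(F)F)Cc4ccc(Cl)cc4)c(C(F)(F)F)nc23)c(C)c1` stands toward the strong end; in this assay compound 2 gives 12 nM. Among the measured compounds shown here, compound 2 differs from compound 1 in more than one place, so the two values show only that compound 2 is the stronger inhibitor, with no single step between them.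

Compound 3 `Cc1cc(C)c(-n2c(Cl)cn3c(CN4CCCC(C)C4)c(C(F)(F)F)nc23)c(C)c1` is the unmeasured analogue of compound 1. The difference is 3-methylpiperidin-1-yl in place of ethyl(2-methylprop-2-en-1-yl)amino on a saturated chain carbon bound to an aromatic carbon: the open amine of compound 1 becomes a six-membered ring from the same atoms joined differently. For the measured compounds named here, no measured pair shows what such a change does on this core. The expected step is small, a 1.2-fold higher number from compound 1 to compound 3 (0.08 log units; within the scatter), and may fall within the scatter. Compound 3 is estimated at 80 nM in this assay, with a range from 25 nM to 250 nM.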

Compound 3, inhibition constant: 5800 nM
The estimate for compound 3 lay 73-fold (1.86 log units) below the measured number; the measured number lies above the stated range.
By their numbers in this assay, from the lowest: compound 2; then compound 1; then compound 3.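

On a saturated chain carbon bound to an aromatic carbon, the amine is far from interchangeable: in this assay, 3-methylpiperidin-1-yl in place of ethyl(2-methylprop-2-en-1-yl)amino gives an 87-fold higher number from compound 1 to compound 3 (1.94 log units; beyond the scatter) on the shared core. The two groups have the same atoms and the same count of heavy atoms, so composition alone does not set the number here; the way those atoms are joined matters at this position. Nothing at hand explains the size of the step.

On these data alone, whether the loss follows from ring closure itself or from the methyl group on the ring remains open, and piperidin-1-yl or morpholin-4-yl at this position would help separate the two. As far as these compounds go, it is also open whether an open-chain amine such as diethylamino would stay nearer compound 1 than compound 3.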